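Benzyloxy for fluorophenylethyl on the carboxamide chain

The compounds below may be only part of what the source reports. "The series", "measured", "known", "first", "only" and "open" are said of these compounds alone.

Compound 1 `CN1CCC(c2ccc3c(c2)oc(=O)n3C(=O)NCCCCc2ccc(F)cc2)CC1` gives 94 nM in an assay on HEK293 cells for inhibition of acid ceramidase (Homo sapiens), read by fluorescence, with stated times of 10 min and 3 h (on this read-out higher numbers stand for weaker inhibition and lower numbers for stronger inhibition), the second highest of the three numbers at hand. Compound 2 `CN1CCC(c2ccc3c(c2)oc(=O)n3C(=O)NCCCCc2ccccc2)CC1=O` gives 105 nM in this assay, within the scatter of compound 1. Compound 3 `O=C(NCCCCc1ccccc1)n1c(=O)oc2ccncc21` gives 6 nM, well beyond the scatter below both. Compound 4 `CN1CCC(c2ccc3c(c2)oc(=O)n3C(=O)NCCOCc2ccccc2)CC1` carries benzyloxy in place of 2-(4-fluorophenyl)ethyl on a saturated chain carbon, two bonds along the chain from an amide-type nitrogen, so the chain keeps its length while the fluorine is lost and an ether oxygen enters. For the measured compounds named here, no measured pair shows this exchange, so the step is judged from compound 1 alone and is expected to be small, if anything toward a higher number. Compound 4 is therefore estimated at 150 nM, within 50 nM to 450 nM, an expected step of a 1.6-fold higher number from compound 1 to compound 4 (0.20 log units; within the scatter).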

Compound 4, half-maximal inhibitory concentration: 215 nM
Compound 4: the middle estimate sits 1.4-fold (0.16 log units) below what was measured; measured number inside the range.
By their numbers in this assay, from the lowest: compound 3; then compounds 1 and 2 (each within the scatter of the next); then compound 4.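

In this assay, benzyloxy in place of 2-(4-fluorophenyl)ethyl on a saturated chain carbon gives a 2.3-fold higher number from compound 1 to compound 4 (0.36 log units; beyond the scatter) as the first step readable in the series. This position therefore responds modestly to an exchange that removes the fluorine and adds an ether oxygen while keeping the aromatic ring. No measurement shown accounts for the step.

Going by these compounds, whether the lost fluorine or the added oxygen carries the step stays open. Also open, on these data alone, is how an amine in place of the ether oxygen, or a longer chain, would read.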